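From compound 3 to compound 4: an aryl exchange

The source may report more compounds than this note shows. Statements on the series, on what has been measured and on what is new or still open speak of the compounds shown alone.

Compound 1 `CCOC(=O)c1c(-c2cc(F)cc(OC)c2)[nH]c2cc(OC)ccc2c1=O`: > 22000 nM
Compound 2 `CCOC(=O)c1c(-c2cccc(OC)c2)[nH]c2cc(OC)c(Cl)cc2c1=O`: > 22000 nM
Compound 3 `CCOC(=O)c1c(-c2cccc(Br)c2)[nH]c2cc(OC)c(Cl)cc2c1=O`: > 22000 nM

In an ADME assay on HEK293 cells (Homo sapiens) for cytotoxicity, read by luminescence, with a stated time of 72 h (on this read-out higher numbers stand for an effect only at larger amounts of compound and lower numbers for an effect already at smaller amounts), compound 3 gives > 22000 nM, which is a limit and not a number. The other two compounds also stand at a limit, so the series offers (the limit of > 22000 nM in this assay, at which 3 of the 3 values shown sit).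

Compound 4 `CCOC(=O)c1c(-c2cc(F)cc(OC)c2)[nH]c2cc(OC)c(Cl)cc2c1=O` carries the next change, 3-fluoro-5-methoxyphenyl in place of 3-bromophenyl on an aromatic carbon, next to the ring nitrogen and ortho to an ethoxycarbonyl group: 3-fluoro-5-methoxyphenyl in place of 3-bromophenyl on an aromatic carbon.

Going by the values given here, the one measured step that bears on this exchange is a step that the two limits leave unreadable from compound 2 to compound 3, with bromo in place of methoxy on an aromatic carbon. It gives no size to carry over. No step beyond the scatter is therefore expected in this assay, and no direction can be assigned. The expected change is a step that the limit leaves unreadable from compound 3 to compound 4.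

For compound 4 the estimate is 25000 nM, with an expected range from 14000 nM to 45000 nM.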

Compound 4, half-maximal effective concentration: > 22000 nM
Compound 4: only a limit was reported (the forecaster's own chance of this, stated with the estimate: 85%); the middle value is on the limit's open side.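

In this assay compound 4 gives > 22000 nM, a limit and not a number. No step from compound 1, compound 2 or compound 3 to compound 4 can be read: the limit of > 22000 nM in this assay, at which 4 of the 4 values shown sit.

The compounds shown leave open whether any change on the shared core would give a readable value.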